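Removing the Chloro on the Amide-Bound Ring

This account rests on a few compounds, and the source may have more. Where it says the series, first, only, none or still open, it means among the compounds named here.

Measured compounds:
compound 1 `Cc1nc(-c2ccc(Cl)cc2)sc1C1SCC(=O)N1c1ccc(F)c(Cl)c1` — 45.2%
compound 2 `Cc1nc(Cc2ccc(Cl)cc2)sc1C1SCC(=O)N1c1ccc(F)c(Cl)c1` — 45.1%
compound 3 `Cc1nc(-c2ccccc2)sc1C1SCC(=O)N1c1ccc(F)c(Cl)c1` — 20.9%

In a functional assay on the whole organism (strain Wistar albino) for inhibition, with Rattus norvegicus as the target, read by paw edema, with stated times of 1 h and 2 h, at a dose of 40 mg/kg by the oral route (a lower number here means less inhibition, a higher number more inhibition at the dose given (going by the name of the read-out)), compound 1 gives 45.2%, the highest of the three numbers, although compound 2 sits within the scatter of it (a number 0.1 percentage points lower from compound 1 to compound 2 (within the scatter)), while compound 3 lies clearly lower (a number 24.3 percentage points lower from compound 1 to compound 3 (beyond the scatter)). Compound 4 `Cc1nc(-c2ccc(Cl)cc2)sc1C1SCC(=O)N1c1ccc(F)cc1` differs from compound 1 by hydrogen in place of chloro on an aromatic carbon.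

Among the compounds with values here, none of the measured steps touches this ring; all three alter the group on the other side of the shared core. The two steps beyond the scatter, a number 24.3 percentage points lower from compound 1 to compound 3 (beyond the scatter) and a number 24.2 percentage points lower from compound 2 to compound 3 (beyond the scatter), both end at a compound lacking any chlorine on that side, and both are of modest size. That offers only an indirect guide, so the expectation for compound 4 is loose: a decrease of modest size in this assay is expected, a number 12.2 percentage points lower from compound 1 to compound 4 (beyond the scatter), with a real chance that the change stays within the scatter. Compound 4 is therefore estimated at 33%, in a range from 18% to 48%.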

Compound 4, a percentage reported as inhibition, in the whole organism at one dose (the size of the read-out at that dose, not a potency): 63.9%
Beside the measured number, compound 4's estimate is 30.9 percentage points below it; measured number above the stated range.
By their numbers in this assay, from the lowest: compound 3; then compounds 2 and 1 (each within the scatter of the next); then compound 4.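

Replacing the chloro ortho to the fluoro group with hydrogen, which turns 3-chloro-4-fluorophenyl into 4-fluorophenyl, is the only step shown at this ring, and in this assay it raises the number (a number 18.7 percentage points higher from compound 1 to compound 4 (beyond the scatter)). The same replacement on the group at the other side of the shared core goes the opposite way (a number 24.3 percentage points lower from compound 1 to compound 3 (beyond the scatter)), so the effect of losing a chloro in this series depends on where it sits, and the drop seen there does not carry over to this ring. Nothing available explains this difference between the two places.

The compounds shown leave open whether the fluoro group contributes to the higher number, and whether a methoxy group or an amine in place of the chloro would give a similar result. They also leave open whether 4-fluorophenyl gives the same rise alongside the 4-chlorobenzyl group of compound 2.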